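Bromo-to-methyl swap on the pyridinyl acrylamide tail

A few compounds are considered here, and "the series" means these few. Any claim that something is new, unique, unknown or untested is made for them only; others in the source may bear on it.

The series shares one core carrying a chloroanilino group. Compound 1 `Clc1cccc(Nc2ncnc3ccc(NCc4cccnc4)cc23)c1` gives 4140 nM in a functional assay on HepG2 cells (Homo sapiens) for antiproliferative activity, read by MTT assay, with a stated time of 48 h; on this read-out higher numbers stand for weaker inhibition and lower numbers for stronger inhibition. Among the compounds with values here, compound 2 `Clc1cccc(Nc2ncnc3ccc(NCc4ncc5ccccc5n4)cc23)c1` gives 5650 nM in this assay, and the step of a 1.4-fold higher number from compound 1 to compound 2 (0.14 log units; within the scatter) is the only single-point change measured so far. Compound 3 `O=C(/C=C/c1cccc(Br)n1)Nc1ccc2ncnc(Nc3cccc(Cl)c3)c2c1` gives 10700 nM in this assay, the highest of the three numbers; it sits within the scatter of compound 2 and beyond the scatter of compound 1.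

Compound 4 `Cc1cccc(/C=C/C(=O)Nc2ccc3ncnc(Nc4cccc(Cl)c4)c3c2)n1` differs from compound 3 by methyl in place of bromo on an aromatic carbon of a six-membered aromatic ring with one nitrogen, next to the ring nitrogen and meta to a large group. Within the data shown here, no measured step in this assay concerns a change at this position or a bromo-to-methyl exchange anywhere; the one measured step concerns a different part of the molecule and was within the scatter. Nothing in the numbers therefore supports a step beyond the scatter in either direction.

The expected step from compound 3 to compound 4 is a 1.1-fold lower number from compound 3 to compound 4 (0.05 log units; within the scatter). Compound 4 is estimated to give 9500 nM in this assay, with a range from 3500 nM to 26000 nM.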

Compound 4, half-maximal inhibitory concentration: 4820 nM
Compound 4: middle estimate off by 2.0-fold (0.29 log units), on the high side; low and high end bracket the measured number.
By their numbers in this assay, from the lowest: compounds 1, 4, 2 and 3 (each within the scatter of the next, the first and the last beyond it).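

Within the data shown here, the exchange of 6-bromopyridin-2-yl for 6-methylpyridin-2-yl gives the only single-point step so far that lies beyond the scatter: in this assay there is a 2.2-fold lower number from compound 3 to compound 4 (0.35 log units; beyond the scatter). The earlier single-point step, at a different part of the molecule, stayed within the scatter, whereas this one, though modest, shows that the group on the aromatic carbon next to the ring nitrogen of the acrylamide tail does change the read-out, with methyl giving the stronger inhibition of the two groups shown there. No measured evidence bears on what lies behind this step.

With only bromo and methyl shown at this place, it stays open whether the step reflects the loss of bromo or the arrival of methyl. Hydrogen, chloro, methoxy or an amine at the same carbon would test this, and an ethyl group would show whether a longer chain is tolerated.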